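Fluoro-methoxyphenyl for acetamidophenyl: toxicity to liver cells

The source may hold more compounds than are shown below. What is called first, only, known or untested is meant among the compounds shown, and "the series" means these compounds.

Compound 1, `CC(C)N(Cc1cccc(OCCCCCC(=O)O)c1)C(=O)c1ccc(-c2cccc3ccccc23)cc1`, gives > 26000 nM in an ADME assay on HepG2 cells (Homo sapiens) for cytotoxicity, read by CellTiter-Glo and resazurin assay, with a stated time of 72 h (a lower number here means that less compound is needed, a higher number that more compound is needed for the effect), which is a limit of the assay.
Compound 2, `CC(=O)Nc1cccc(-c2ccc(C(=O)N(Cc3cccc(OCCCCCC(=O)O)c3)C(C)C)cc2)c1`, gives > 26000 nM in this assay, again a limit.
Compound 3, `CCOC(=O)CCCCCOc1cccc(CN(C(=O)c2ccc(-c3cccc(NC(C)=O)c3)cc2)C(C)C)c1`, gives > 26000 nM in this assay, again a limit.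

Compound 3 therefore stands at the limit, and so do the other two, as the limit of > 26000 nM in this assay, at which 3 of the 3 values shown sit, states. The two measured steps give no readable size: a step that the two limits leave unreadable from compound 1 to compound 2 and a step that the two limits leave unreadable from compound 2 to compound 3. The change now followed is 3-fluoro-5-methoxyphenyl in place of 3-acetamidophenyl on an aromatic carbon, giving compound 4, `CCOC(=O)CCCCCOc1cccc(CN(C(=O)c2ccc(-c3cc(F)cc(OC)c3)cc2)C(C)C)c1`. Going by the values given here, no measured step bears on it with a readable size, so the expectation rests only on the fact that every compound shown sits at the limit. Compound 4 is expected to sit there as well, so the step of a number no higher from compound 3 to compound 4 (the limit leaves the size open) is expected to be none beyond the scatter, and most likely the assay will again report only a limit. Compound 4 is estimated at 26000 nM, with a range from 13000 nM to 52000 nM.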

Compound 4, half-maximal effective concentration: > 26000 nM
Compound 4: a limit, no number; the forecaster's own chance of this, stated with the estimate: 80%; the middle value sits exactly at the limit.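

Going by these compounds alone, compound 3 and compound 4 both give only a limit, so the step between them cannot be read, and neither can the earlier steps. The compounds shown leave open what concentration each would need for the effect in this assay, and whether any change alters it, since all share one result: the limit of > 26000 nM in this assay, at which 4 of the 4 values shown sit.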